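A few compounds are considered here, and "the series" means these few. Any claim that something is new, unique, unknown or untested is made for them only; others in the source may bear on it.

Measured so far:
Compound 1, `COc1ncnc2c1c(-c1ccsc1)cn2[C@@H]1O[C@H](CO)[C@@H](O)[C@H]1O`: 130 nM
Compound 2, `COc1ncnc2c1c(-c1cccs1)cn2[C@@H]1O[C@H](CO)[C@@H](O)[C@H]1O`: 80 nM
Compound 3, `CNc1ncnc2c1c(-c1cccs1)cn2[C@@H]1O[C@H](CO)[C@@H](O)[C@H]1O`: > 20000 nM

In a functional assay on HL-60 cells (Homo sapiens) for antiproliferative activity, read by XTT assay, with a stated time of 72 h (a lower number here means a stronger inhibitor, a higher number a weaker inhibitor), compound 2 gives 80 nM and compound 1 gives 130 nM. Between them lies (thiophen-3-yl in place of thiophen-2-yl on an aromatic carbon), and that step is a 1.6-fold higher number from compound 2 to compound 1 (0.21 log units; within the scatter). For compound 3 the result in this assay is only a limit, > 20000 nM. The change methylamino in place of methoxy on an aromatic carbon thus brings an at least 250-fold higher number from compound 2 to compound 3 (2.39 log units; beyond the scatter), the step resting on (the limit of > 20000 nM in this assay, at which 1 of the 3 values shown sits).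

Compound 4, `CNc1ncnc2c1c(-c1ccsc1)cn2[C@@H]1O[C@H](CO)[C@@H](O)[C@H]1O`, has not been measured in this assay. It differs from compound 3 by thiophen-3-yl in place of thiophen-2-yl on an aromatic carbon, the same change that separates compound 2 from compound 1, on the same place. Because that change gave a 1.6-fold higher number from compound 2 to compound 1 (0.21 log units; within the scatter), compound 4 is expected to stay close to compound 3, whose result in this assay is a limit. The estimated step for compound 4 is therefore a step that the limit leaves unreadable from compound 3 to compound 4. Compound 4 is expected to give about 30000 nM in this assay, most likely reported again as a limit, with a range of 12000 nM to 80000 nM.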

Compound 4, half-maximal inhibitory concentration: > 20000 nM
Compound 4: only a limit was reported (the forecaster's own chance of this, stated with the estimate: 85%); the middle value is on the limit's open side.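

In this assay, methylamino in place of methoxy on an aromatic carbon brings an at least 150-fold higher number from compound 1 to compound 4 (2.18 log units; beyond the scatter), so a large step in the same direction appears on both the thiophen-2-yl and the thiophen-3-yl cores: the same change on two cores in this assay, an at least 250-fold higher number (2.39 log units; beyond the scatter) from compound 2 to compound 3 and an at least 150-fold higher number (2.18 log units; beyond the scatter) from compound 1 to compound 4; the limit leaves it open whether they differ Compound 4 gives > 20000 nM, which is a limit, and compound 3 also sits at a limit, so the step between these two compounds cannot be read. The change therefore carries over from one core to the other in direction and in being large, but the true size of the step on either core is not known: the limit of > 20000 nM in this assay, at which 2 of the 4 values shown sit.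

The compounds shown leave open whether another group on that same aromatic carbon, such as ethoxy, an unsubstituted amino group or dimethylamino, would stay close to the methoxy compounds or fall to the limit. They also leave open whether a phenyl or furan-2-yl group in place of the thiophene would keep the methoxy result.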